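The source may hold more compounds than are shown below. What is called first, only, known or untested is meant among the compounds shown, and "the series" means these compounds.

Of the compounds shown here, three built on a shared core have been measured in a functional assay on CHO cells for antagonist activity at prostaglandin E2 receptor EP3 subtype (Homo sapiens), read by cAMP accumulation; a higher number here means a weaker inhibitor, a lower number a stronger inhibitor. Compound 1 `CC(C)C(Cc1ncc[nH]1)c1ccc(-c2ccc3cccc(F)c3c2)[nH]c1=O` gives 76 nM in this assay; compound 2 `CC(C)C(c1ccc(-c2ccc3cccc(F)c3c2)[nH]c1=O)N1CCCCC1=O` gives 40 nM; compound 3 `CC(C)C(c1cnc(N)s1)c1ccc(-c2ccc3cccc(F)c3c2)[nH]c1=O` gives 39 nM. Compound 3 has the lowest of the three numbers, but the steps that lead to it are small: a 1.0-fold lower number from compound 2 to compound 3 (0.01 log units; within the scatter) and a 1.9-fold lower number from compound 1 to compound 3 (0.29 log units; within the scatter), so all three sit within the scatter of one another and no order among them can be claimed.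

Compound 4 `CC(C)C(c1ccc(-c2ccc3cccc(F)c3c2)[nH]c1=O)N1CCNC1=O` differs from compound 3 at the same position where the three measured compounds differ: 2-oxoimidazolidin-1-yl in place of 2-amino-1,3-thiazol-5-yl on a saturated chain carbon bound to an aromatic carbon and a saturated chain carbon. Within the data shown here, the steps that bear on this position are all small: a 1.9-fold lower number from compound 1 to compound 2 (0.28 log units; within the scatter), a 1.9-fold lower number from compound 1 to compound 3 (0.29 log units; within the scatter) and a 1.0-fold lower number from compound 2 to compound 3 (0.01 log units; within the scatter). Every group tried there so far has given a number within the scatter of the others, and the group that enters in compound 4 is, like that of compound 2, a ring carrying a carbonyl attached through a ring nitrogen. On that basis no step beyond the scatter is expected in this assay, in either direction.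

For compound 4 the estimate in this assay is 45 nM, with a range from 18 nM to 110 nM. This corresponds to an expected step of a 1.2-fold higher number from compound 3 to compound 4 (0.06 log units; within the scatter).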

Compound 4, half-maximal inhibitory concentration: 28 nM
Beside the measured number, compound 4's estimate is 1.6-fold (0.21 log units) above it; low and high end bracket the measured number.
By their numbers in this assay, from the lowest: compounds 4, 3, 2 and 1 (each within the scatter of the next, the first and the last beyond it).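

In this assay this position now shows its first step beyond the scatter, though a modest one: a 2.7-fold lower number from compound 1 to compound 4 (0.43 log units; beyond the scatter), with 2-oxoimidazolidin-1-yl in place of (1H-imidazol-2-yl)methyl. The other two steps to the new group stay within the scatter, a 1.4-fold lower number from compound 3 to compound 4 (0.14 log units; within the scatter) and a 1.4-fold lower number from compound 2 to compound 4 (0.15 log units; within the scatter), so 2-oxoimidazolidin-1-yl, 2-amino-1,3-thiazol-5-yl and 2-oxopiperidin-1-yl cannot be ordered among themselves, and the position tolerates both a five-membered aromatic ring and a five-membered non-aromatic ring without a separable difference. Among these compounds, no measurement is available that explains the one step beyond the scatter.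

On these data alone, it remains open whether the gap between the two end compounds reflects anything particular to the (1H-imidazol-2-yl)methyl group, since compound 2 and compound 3 each lie within the scatter of both ends. As far as these compounds go, it is also open whether a simple amine, a carboxylic acid or a longer chain on this saturated chain carbon would leave the narrow range seen so far, and whether a methyl group on the free ring nitrogen of 2-oxoimidazolidin-1-yl would change the number.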